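The compounds below may be only part of what the source reports. "The series", "measured", "known", "first", "only" and "open" are said of these compounds alone.

The series shares one core, seen in compound 1 `COc1ccccc1OCCNc1cnn(Cc2ccc(OC)c(OCC3CC3)c2)c(=O)c1Cl`, compound 2 `COc1ccccc1OCCNc1ccc(=O)n(Cc2ccc(OC)c(OC3CCCC3)c2)n1` and compound 3 `COc1ccc(Cn2ncc(NCCOc3ccccc3OC)c(Cl)c2=O)cc1OC`. In a functional assay on AGS cells (Homo sapiens) for antiproliferative activity, read by MTT assay, with a stated time of 48 h (a lower number here means a stronger inhibitor of growth, a higher number a weaker inhibitor of growth), compound 1 gives > 100000 nM, which is a limit of the assay rather than a number. Compound 2 gives > 100000 nM, likewise a limit. Compound 3 gives > 100000 nM, again a limit. Compound 3 therefore stands exactly where every other value shown stands, because of the limit of > 100000 nM in this assay, at which 3 of the 3 values shown sit. The only single-point step shown, a step that the two limits leave unreadable from compound 1 to compound 3, is left without a readable size by those two limits.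

Compound 4 `COc1ccccc1OCCNc1cnn(Cc2ccc(OC)c(-c3cccc(Cl)c3)c2)c(=O)c1Cl` differs from compound 3 by 3-chlorophenyl in place of methoxy on an aromatic carbon. No measured step bears directly on this change; the one step shown is unreadable, and every value shown is a limit. From these data alone no shift beyond the scatter can be foreseen, so compound 4 is expected to stay near the limit, with a number no higher from compound 3 to compound 4 (the limit leaves the size open) as the estimated step. Compound 4 is accordingly estimated at 100000 nM, between 30000 nM and 300000 nM.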

Compound 4, concentration for 50% growth inhibition: > 100000 nM
Compound 4 was reported as a limit; the forecaster's own chance of this, stated with the estimate: 70%; the middle value sits exactly at the limit.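

Compound 4 gives > 100000 nM in this assay, which is a limit of the assay and not a number. The steps from compound 3 to compound 4 and from compound 1 to compound 4 cannot be read. The compounds shown leave open which change to the shared core, if any, would give a readable value, as every value sits at one limit: the limit of > 100000 nM in this assay, at which 4 of the 4 values shown sit.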